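A few compounds are considered here, and "the series" means these few. Any claim that something is new, unique, unknown or untested is made for them only; others in the source may bear on it.

Measured compounds in a functional assay on MCF7 cells (Homo sapiens) for cytotoxicity, read by MTT assay, with a stated time of 24 h; on this read-out lower numbers stand for stronger inhibition and higher numbers for weaker inhibition:

compound 1 `Cn1c(-c2ccc(NC(=O)CCl)cc2)nc(-c2ccccc2)c1-c1ccccc1`: 42.6 ug/mL
compound 2 `Cn1nnnc1SCC(=O)Nc1ccc(-c2nc(-c3ccccc3)c(-c3ccccc3)n2C)cc1`: 4.5 ug/mL
compound 3 `Cn1c(-c2ccc(NC(=O)CSC3=NCCS3)cc2)nc(-c2ccccc2)c1-c1ccccc1`: 26.7 ug/mL

Compound 3 stands second highest of the three numbers. Its nearest neighbour is compound 1, a gap within the scatter; its furthest is compound 2, a 5.9-fold higher number from compound 2 to compound 3 (0.77 log units; beyond the scatter), a modest difference.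

Compound 4 `CN1CCN(CC(=O)Nc2ccc(-c3nc(-c4ccccc4)c(-c4ccccc4)n3C)cc2)CC1` is not yet measured. Relative to compound 3 the change is a group of 7 heavy atoms (5 carbon, 2 nitrogen; one six-membered non-aromatic ring with 2 hetero atoms) in place of a group of 6 heavy atoms (3 carbon, 1 nitrogen, 2 sulfur; one five-membered non-aromatic ring with 2 hetero atoms), on a saturated chain carbon bound to a carbonyl carbon.

Every measured step in this series varies the same position, the saturated chain carbon bound to the carbonyl carbon, so all three bear on the new step in a general way, though none introduces the 4-methylpiperazin-1-yl group. Exchanging chloro for the five-membered non-aromatic ring gave a 1.6-fold lower number from compound 1 to compound 3 (0.20 log units; within the scatter), which stays within the scatter. Exchanging chloro for the (1-methyl-1H-tetrazol-5-yl)sulfanyl group gave a 9.5-fold lower number from compound 1 to compound 2 (0.98 log units; beyond the scatter), a modest step, and the reverse exchange of the aromatic ring for the non-aromatic ring gave a 5.9-fold higher number from compound 2 to compound 3 (0.77 log units; beyond the scatter). Substituent changes at this position thus range from no effect to a modest shift in this assay, with no precedent for a larger move.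

Compound 4 is therefore expected near compound 3, with a step of about a 1.3-fold lower number from compound 3 to compound 4 (0.13 log units; within the scatter), not clearly beyond the scatter. The estimate for compound 4 is 20 ug/mL, with a range from 6 ug/mL to 60 ug/mL.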

Compound 4, half-maximal inhibitory concentration: 76.5 ug/mL
Compound 4: the middle estimate sits 3.8-fold (0.58 log units) below what was measured; measured number above the stated range.
By their numbers in this assay, from the lowest: compound 2; then compounds 3, 1 and 4 (each within the scatter of the next, the first and the last beyond it).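

At the saturated chain carbon bound to a carbonyl carbon, the series now holds its first large step: in this assay, 4-methylpiperazin-1-yl in place of (1-methyl-1H-tetrazol-5-yl)sulfanyl (a 17-fold higher number from compound 2 to compound 4 (1.23 log units; beyond the scatter)) widens the span seen at this position, and compound 2 stands apart from the other three. The six-membered non-aromatic ring is also not interchangeable with the sulfur-linked five-membered non-aromatic ring (a 2.9-fold higher number from compound 3 to compound 4 (0.46 log units; beyond the scatter)), although the same group set against chloro makes no difference beyond the scatter (a 1.8-fold higher number from compound 1 to compound 4 (0.25 log units; within the scatter)). No measurement at hand accounts for these steps.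

From the compounds shown here alone, it remains open whether the low number of compound 2 goes with the tetrazole ring, its methyl group or the sulfur link; a 1H-tetrazol-5-ylsulfanyl or a 1-methyl-1H-imidazol-2-ylsulfanyl group on the same carbon would begin to separate these. Going by these compounds, it is equally open whether the number of compound 4 belongs to the piperazine ring as such or to any amine at this place, and morpholin-4-yl or an open-chain dimethylamino group would bear on that.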